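Removing the ethynyl group from compound 2

This account rests on a few compounds, and the source may have more. Where it says the series, first, only, none or still open, it means among the compounds named here.

Measured compounds:
compound 1 `CC(Sc1nc2c(cnn2C)c(=O)n1-c1ccccc1)c1ccccn1`: 89 nM
compound 2 `C#Cc1ccc(-n2c(SC(C)c3ccccc3)nc3c(cnn3C)c2=O)cc1`: 520 nM

In an assay on isolated protein for inhibition of Retinaldehyde dehydrogenase 3 (Homo sapiens) (a lower number here means a stronger inhibitor, a higher number a weaker inhibitor), compound 2 gives 520 nM, the highest of the two numbers, while compound 1 gives 89 nM, a gap beyond the usual scatter. Compound 3 `CC(Sc1nc2c(cnn2C)c(=O)n1-c1ccccc1)c1ccccc1` is not yet measured. It differs from compound 2 by hydrogen in place of ethynyl on an aromatic carbon. Among the compounds with values here, no measured pair shows this change alone, so its size is uncertain; a modest decrease in this assay is expected, a 2.6-fold lower number from compound 2 to compound 3 (0.41 log units; beyond the scatter), since no step here is known. For compound 3 the estimate is 200 nM, with a range from 60 nM to 700 nM.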

Compound 3, half-maximal inhibitory concentration: 73 nM
Beside the measured number, compound 3's estimate is 2.7-fold (0.44 log units) above it; the range from low to high includes it.
By their numbers in this assay, from the lowest: compounds 3 and 1 (each within the scatter of the next); then compound 2.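

In this assay the ethynyl group on the aromatic carbon para to a large group proves a clear liability (a 7.1-fold lower number from compound 2 to compound 3 (0.85 log units; beyond the scatter)). On the saturated chain carbon, by contrast, phenyl and pyridin-2-yl cannot be told apart (a 1.2-fold lower number from compound 1 to compound 3 (0.09 log units; within the scatter)). No available evidence accounts for either result.

Open, on these data alone, is how a methoxy group or an amine on that same aromatic carbon would fare in this assay. Also open, as far as these compounds go, is whether a pyridin-3-yl group on the chain carbon would match these two rings.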